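The source may hold more compounds than are shown below. What is called first, only, known or untested is meant among the compounds shown, and "the series" means these compounds.

Compound 1 `CC(C)Nc1nc(NCc2ccco2)c2ccccc2n1` holds the only numbered result in this set: in an ADME assay on J774.A1 cells (Mus musculus) for cytotoxicity, read by MTT assay, with a stated time of 72 h (a higher number here means that more compound is needed for the effect, a lower number that less compound is needed), compound 1 gives 17000 nM. Compound 2 `Cc1ccc2nc(NC(C)C)nc(NCc3ccco3)c2c1` reaches only a limit of the assay, and in this assay compound 2 gives > 33000 nM. Among the compounds with values here, the single measured step, an at least 1.9-fold higher number from compound 1 to compound 2 (0.28 log units; that floor lies within the scatter), is a methyl in place of hydrogen on an aromatic carbon. Compound 3 `COc1ccc2c(NCc3ccco3)nc(NC(C)C)nc2c1` differs from compound 1 by methoxy in place of hydrogen on an aromatic carbon. Within the data shown here, only that one step bears on the change, and its floor lies within the scatter, so the expected step is a 1.3-fold higher number from compound 1 to compound 3 (0.11 log units; within the scatter), with nothing beyond the scatter foreseen. Compound 3 is therefore estimated at 22000 nM, between 8000 nM and 60000 nM.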

Compound 3, half-maximal effective concentration: 16000 nM
Estimate against measurement, compound 3: 1.4-fold (0.14 log units) above; the range from low to high includes it.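

Methoxy in place of hydrogen on this aromatic carbon, meta to a fused ring and para to a fused ring, gives a step that can be read in full in this assay: a 1.1-fold lower number from compound 1 to compound 3 (0.03 log units; within the scatter). Unlike the methyl step, which has only a floor, this one is a measured size, and it stays within the scatter. Compound 2 remains a limit of the assay: the limit of > 33000 nM in this assay, at which 1 of the 3 values shown sits.

As far as these compounds go, whether an amine or a carboxylic acid on this carbon would move the number beyond the scatter stays open. So does whether methoxy on another carbon of this ring would.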